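The compounds below may be only part of what the source reports. "The series", "measured", "known", "first", "only" and "open" are said of these compounds alone.

Going by the values given here, in an ADME assay on HeLa cells (Homo sapiens) for cytotoxicity, read by microscopy (on this read-out higher numbers stand for lower toxicity in this test and lower numbers for higher toxicity in this test), compound 2 `COc1ccc(-c2nc(SC)nc(NCCCCNc3ccnc4cc(Cl)ccc34)c2C#N)cc1OC` gives 100000 nM, the highest of the two numbers measured so far, while compound 1 `COc1ccc(-c2nc(SC)nc(NCCCCNc3ccnc4cc(Cl)ccc34)c2C#N)cc1` gives 20000 nM. Among the compounds with values here, only one measured step exists, a 5.0-fold higher number from compound 1 to compound 2 (0.70 log units; beyond the scatter), and it is the one that bears on the move to compound 3 `CSc1nc(NCCCCNc2ccnc3cc(Cl)ccc23)c(C#N)c(-c2ccc(C)cc2)n1`, which has not yet been tested. Compound 3 differs from compound 2 in one place: 4-methylphenyl in place of 3,4-dimethoxyphenyl on an aromatic carbon. The change removes the two methoxy groups, one of which had accompanied the rise in the number, and brings in a methyl group on the ring in their place. Compound 3 is expected to land lower than compound 2 because a 5.0-fold higher number from compound 1 to compound 2 (0.70 log units; beyond the scatter) came with adding a methoxy, and the expected step is a 6.7-fold lower number from compound 2 to compound 3 (0.82 log units; beyond the scatter). Compound 3 is therefore estimated at 15000 nM, with a likely range from 5000 nM to 50000 nM.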

Compound 3, minimum cytotoxic concentration: 100000 nM
Estimate against measurement, compound 3: 6.7-fold (0.82 log units) below; the measured number lies above the stated range.
By their numbers in this assay, from the lowest: compound 1; then compounds 2 and 3 (each within the scatter of the next).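

In this assay, 4-methylphenyl in place of 3,4-dimethoxyphenyl on this aromatic carbon gives no change at the digits printed from compound 2 to compound 3 (within the scatter), so losing both methoxy groups does not bring the number down. Methyl in place of methoxy gives a 5.0-fold higher number from compound 1 to compound 3 (0.70 log units; beyond the scatter), which shows that the higher number also appears with a ring that carries no oxygen, and so does not depend on a second methoxy group. No measurement is available to explain why these two different rings give matching numbers.

The compounds shown leave open whether a plain phenyl ring, with nothing attached, would sit with compound 1 or with compounds 2 and 3. They also leave open how an amine, a carboxylic acid or a longer chain such as propyl on this ring would read in this assay.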